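Amide-side heteroaryl swap on the shared core

The compounds below may be only part of what the source reports. "The series", "measured", "known", "first", "only" and "open" are said of these compounds alone.

Measured compounds:
Compound 1, `C[C@@H]1CN(c2sc(C(F)(F)F)nc2-c2nc3ccccc3[nH]2)CCN1C(=O)Cn1cccn1`, gives 44 mL.min-1.g-1 in an ADME assay on microsomes from liver (Homo sapiens) for metabolic stability, read by LC-MS, using NADPH, with a stated time of 15 min, tested at 1 uM; a higher number here means faster removal of the compound, a lower number slower removal.
Compound 2, `Cc1nc(C)n(CC(=O)N2CCN(c3sc(C(F)(F)F)nc3-c3nc4ccc(C5CCOCC5)cc4[nH]3)C[C@H]2C)n1`, gives 18 mL.min-1.g-1 in this assay.
Compound 3, `Cc1nc(C)n(CC(=O)N2CCN(c3sc(C(F)(F)F)nc3-c3nc4ccc(C5CCN(C)CC5)cc4[nH]3)C[C@H]2C)n1`, gives 27 mL.min-1.g-1 in this assay.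

Compound 1 carries the highest number of the three. Its gap to compound 3 is within the scatter, so no order between those two can be read; its gap to compound 2 is beyond the scatter, so compound 1 is cleared faster than compound 2.

Compound 4, `C[C@@H]1CN(c2sc(C(F)(F)F)nc2-c2nc3ccccc3[nH]2)CCN1C(=O)Cn1cnc2cccnc21`, is not yet measured. It differs from compound 1 in one place: a group of 9 heavy atoms (6 carbon, 3 nitrogen; one five-membered aromatic ring with 2 hetero atoms, one six-membered aromatic ring with 1 hetero atom) in place of a group of 5 heavy atoms (3 carbon, 2 nitrogen; one five-membered aromatic ring with 2 hetero atoms), on a saturated chain carbon bound to a carbonyl carbon.

Among the compounds with values here, only one measured step exists, a 1.5-fold higher number from compound 2 to compound 3 (0.18 log units; within the scatter). That step changes a group on an aromatic carbon of the benzimidazole side, not the group on the saturated chain carbon bound to the carbonyl carbon, so it does not bear directly on the change from compound 1 to compound 4. It does show that a single-group exchange elsewhere on the same core left this assay within the scatter. Within the data shown here, no measured compound varies the group at the position touched here, so there is no direct guide.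

With that, a step of a 1.1-fold higher number from compound 1 to compound 4 (0.06 log units; within the scatter) is expected, that is, no movement beyond the scatter. Compound 4 is therefore estimated at 50 mL.min-1.g-1, within 25 mL.min-1.g-1 to 100 mL.min-1.g-1.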

Compound 4, intrinsic clearance in microsomes in the Homo sapiens assay: 89 mL.min-1.g-1
Compound 4: the middle estimate sits 1.8-fold (0.25 log units) below what was measured; low and high end bracket the measured number.
By their numbers in the Homo sapiens assay, from the lowest: compounds 2, 3 and 1 (each within the scatter of the next, the first and the last beyond it); then compound 4.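

Within the data shown here, in the Homo sapiens assay, placing the group of 9 heavy atoms in place of 1H-pyrazol-1-yl, on a saturated chain carbon bound to a carbonyl carbon, gives a 2.0-fold higher number from compound 1 to compound 4 (0.31 log units; beyond the scatter), so this position can move the read-out, whereas the only earlier step, made on an aromatic carbon, stayed within the scatter. In a physicochemical assay for solubility, in simulated intestinal fluid (a higher number here means a more soluble compound, a lower number a less soluble compound), compound 1 gives 734 ug/mL and compound 4 gives 214 ug/mL, which is also a 3.4-fold lower number from compound 1 to compound 4 (0.54 log units; beyond the scatter). The added six-membered aromatic ring therefore comes with both faster removal and lower solubility, and the solubility loss is the larger and clearer of the two shifts: the measured solubility of compound 1, 734 ug/mL, and of compound 4, 214 ug/mL, a 3.4-fold lower number (0.54 log units; beyond the scatter)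

This single pair does not separate the effect of the number of heavy atoms from that of the added ring nitrogen, so neither can yet be credited with the two shifts. Also open, going by these compounds, is how an amine, a carboxylic acid or a longer chain on this same carbon would behave in the two read-outs, and whether the step would hold on the cores of compound 2 and compound 3.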